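Swapping the amide substituent: from compound 1 to compound 4

The source may report more compounds than this note shows. Statements on the series, on what has been measured and on what is new or still open speak of the compounds shown alone.

Measured compounds:
- compound 1, `CCNC(=O)/C=C1\CCc2ccc(F)cc21`, 45%
- compound 2, `CNC(=O)/C=C1\CCc2ccc(Cl)cc21`, 0%
- compound 3, `O=C(/C=C1\CCc2ccc(Br)cc21)NC1CC1`, 29%

Three compounds share one core and differ in the group on the amide and in the halogen on the aromatic ring. In a functional assay on the whole organism with Rattus norvegicus as the target, at a dose of 20 mg/kg by the oral route (on this read-out higher numbers stand for more inhibition at the one dose given (going by the name of the read-out) and lower numbers for less inhibition), compound 1 gives 45%, the highest of the three numbers. The nearest is compound 3, whose number in this assay is 29%, a gap beyond the usual scatter. The furthest is compound 2, which in this assay gives 0%, also beyond the scatter.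

Compound 4, `O=C(/C=C1\CCc2ccc(F)cc21)N1CCC1`, has not yet been measured. It keeps the fluorine of compound 1 and changes only the amide: azetidin-1-yl in place of ethylamino on a carbonyl carbon. Going by the values given here, no measured pair shows this kind of change, so its size cannot be read from the data; the three measured compounds all carry an amide with a hydrogen on the nitrogen, while compound 4 does not.

Because compound 1 stands at 45% and the closest known variation of the amide group, in compound 3, reached only 29%, compound 4 is expected to land somewhat lower, a step of a number 20 percentage points lower from compound 1 to compound 4 (beyond the scatter) in this assay. The estimate for compound 4 in this assay is 25%, with a range from 0% to 55%.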

Compound 4, a percentage reported as inhibition, in the whole organism at one dose (the size of the read-out at that dose, not a potency): 14%
Compound 4: the middle estimate sits 11 percentage points above what was measured; the measured number falls inside the stated range.
By their numbers in this assay, from the lowest: compound 2; then compound 4; then compound 3; then compound 1.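

In this assay, going by these compounds alone, the step from ethylamino to azetidin-1-yl on a carbonyl carbon is the first comparison in which only one place changes: with the fluorine held constant, the result is a number 31 percentage points lower from compound 1 to compound 4 (beyond the scatter). This shows that the amide substituent alone can shift the read-out substantially, something compounds 1, 2 and 3 could not show, as each of them differs from the others in both the amide group and the halogen. Within the data shown here, the single change removes the amide hydrogen and also brings in a four-membered ring, so the step cannot assign the drop to either feature, and no separate measurement offers an explanation for it.

The compounds shown leave open whether the amide hydrogen or the ring matters more: a dimethylamino group would lack that hydrogen without having a ring, while a cyclopropylamino group on the fluorine-bearing core would keep the hydrogen and carry a ring. A pyrrolidin-1-yl group would further show whether the size of the ring on the amide nitrogen matters.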